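The compounds below may be only part of what the source reports. "The series", "measured", "known", "first", "only" and "open" are said of these compounds alone.

Compound 1 `O=C(Nc1cccc(-c2nccs2)c1)C(Cl)Cl`. In a functional assay on NCI-H460 cells (Homo sapiens) for cytotoxicity, read by MTT assay, with a stated time of 68 h (on this read-out lower numbers stand for stronger inhibition and higher numbers for weaker inhibition), compound 1 reaches only the limit of the assay, > 50000 nM.
Compound 2 `COc1ccc(-c2cccc(NC(=O)C(Cl)Cl)c2)cc1`. In this assay compound 2 gives 43300 nM.
Compound 3 `Cc1ccc(-c2cccc(NC(=O)C(Cl)Cl)c2)cc1`. In this assay compound 3 gives 8000 nM.

Compound 3 stands at the lowest of the two numbers shown; its nearest neighbour is compound 2, and the one measured step, a 5.4-fold lower number from compound 2 to compound 3 (0.73 log units; beyond the scatter), separates them. Compound 1 stands apart, since the limit of > 50000 nM in this assay, at which 1 of the 3 values shown sits, is all that is known of it.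

Compound 4 `O=C(Nc1cccc(-c2ccccc2)c1)C(Cl)Cl` differs from compound 3 by hydrogen in place of methyl on an aromatic carbon. Within the data shown here, the only measured step at this position swaps methoxy for methyl, and it favours the methyl; no measured pair shows what removing the methyl altogether does. Because the methyl carries the lowest number in a 5.4-fold lower number from compound 2 to compound 3 (0.73 log units; beyond the scatter), compound 4 is expected to lose some of that gain, with a step of a 1.9-fold higher number from compound 3 to compound 4 (0.27 log units; within the scatter) that may not clear the scatter. Compound 4 is therefore estimated at 15000 nM, within a range from 5000 nM to 45000 nM.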

Compound 4, half-maximal inhibitory concentration: 20200 nM
Compound 4: the middle estimate sits 1.3-fold (0.13 log units) below what was measured, within the range that was stated.
By their numbers in this assay, from the lowest: compound 3; then compound 4; then compound 2. At a limit, above all of these: compound 1.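

Removing the methyl gives a result that the methoxy-to-methyl step could not: a 2.5-fold higher number from compound 3 to compound 4 (0.40 log units; beyond the scatter) shows that the methyl on this aromatic carbon, para to a large group, goes with a lower number than hydrogen itself. Hydrogen also differs from methoxy, with a 2.1-fold lower number from compound 2 to compound 4 (0.33 log units; beyond the scatter) in the same assay, so compound 3, compound 4 and compound 2 stand in the order methyl, hydrogen, methoxy, each step beyond the scatter. Phenyl in place of 1,3-thiazol-2-yl gives an at least 2.4-fold lower number from compound 1 to compound 4 (0.39 log units; beyond the scatter) as the other change, and that step is only a bound because its starting value is a limit: the limit of > 50000 nM in this assay, at which 1 of the 4 values shown sits.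

From the compounds shown here alone, whether an ethyl group, a chlorine atom or an amine on this carbon would fit that order stays open. The compounds shown also leave open what a pyridine ring would give in place of the phenyl.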